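A few compounds are considered here, and "the series" means these few. Any claim that something is new, unique, unknown or untested is made for them only; others in the source may bear on it.

Within the data shown here, in a functional assay on B16-F0 cells (Mus musculus) for inhibition, read by CCK-8 assay, with a stated time of 48 h (a lower number here means a stronger inhibitor, a higher number a weaker inhibitor), compound 2 (`COc1cc(-c2ccnc3cc(-c4ccc(N(C)C)cc4)nn23)cc(OC)c1OC`) gives 702 nM and holds the lower of the two numbers so far. Against it, compound 1 (`COc1cc(-c2ccnc3cc(-c4ccc(C(F)(F)F)cc4)nn23)cc(OC)c1OC`) gives 1770 nM as the only other number. Compound 3 (`C=Cc1ccc(-c2cc3nccc(-c4cc(OC)c(OC)c(OC)c4)n3n2)cc1`) carries vinyl in place of dimethylamino on an aromatic carbon, para to a large group (vinyl in place of dimethylamino on an aromatic carbon). Among the measured compounds shown here, only one measured step bears on this place: a 2.5-fold lower number from compound 1 to compound 2 (0.40 log units; beyond the scatter) with dimethylamino in place of trifluoromethyl, a modest change beyond the scatter. For the measured compounds named here, no compound with vinyl has been measured, so that step sets a scale and not a value. Dimethylamino leaves in compound 3, and the one comparison available favours it, so a small move to a higher number in this assay is expected, no larger than a 2.5-fold lower number from compound 1 to compound 2 (0.40 log units; beyond the scatter) and possibly not beyond the scatter. The expected change is a 1.6-fold higher number from compound 2 to compound 3 (0.20 log units; within the scatter) on this reasoning. Going by the values given here, for compound 3 the estimated value is 1100 nM with an expected range from 400 nM to 2800 nM given the single step available.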

Compound 3, half-maximal inhibitory concentration: 788 nM
The estimate for compound 3 lay 1.4-fold (0.14 log units) above the measured number; measured number inside the range.
By their numbers in this assay, from the lowest: compounds 2 and 3 (each within the scatter of the next); then compound 1.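

In this assay, vinyl in place of dimethylamino on an aromatic carbon, para to a large group, gives no change that can be read (a 1.1-fold higher number from compound 2 to compound 3 (0.05 log units; within the scatter)), even though vinyl enters with no nitrogen and no hydrogen-bond acceptor. Vinyl in place of trifluoromethyl at the same place gives a step beyond the scatter (a 2.2-fold lower number from compound 1 to compound 3 (0.35 log units; beyond the scatter)), as dimethylamino did (a 2.5-fold lower number from compound 1 to compound 2 (0.40 log units; beyond the scatter)), so among these three compounds the separation from compound 1 does not depend on a nitrogen or a hydrogen-bond acceptor in the entering group. No measurement bears on what lies behind these numbers.

On these data alone, it remains open whether a carboxylic acid, a primary amine or a longer alkyl chain at this place would stay level with compound 2 and compound 3 or would move apart from them, and so whether trifluoromethyl is an exception or one end of a wider spread. As far as these compounds go, all three compounds share the rest of the structure, so whether these steps hold when another part of the shared core changes also remains open.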